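Bromine for Chlorine in an Analgesic Series

A few compounds are considered here, and "the series" means these few. Any claim that something is new, unique, unknown or untested is made for them only; others in the source may bear on it.

Measured compounds:
Compound 1, `Cc1[nH]c2ccc(Cl)cc2c1SC1CCNCC1`: in a functional assay on the whole organism with Mus musculus as the target, in the hot plate test (a lower number here means that less compound is needed, a higher number that more compound is needed for the effect), compound 1 gives 9.9 mg/kg.
Compound 2, `Cc1[nH]c2ccc(Br)cc2c1SC1CCNCC1`: in this assay compound 2 gives 3.1 mg/kg.
Compound 3, `CON1CCC(Sc2c[nH]c3ccc(Cl)cc23)CC1`: in this assay compound 3 gives 2.3 mg/kg.

Compounds 1 and 2 share one core and differ in a single place: bromo in place of chloro on an aromatic carbon. That change gave a 3.2-fold lower number from compound 1 to compound 2 (0.50 log units; beyond the scatter). Compound 3 carries a different core; the difference between the cores of compound 1 and compound 3 is not broken down here. Compound 4, `CON1CCC(Sc2c[nH]c3ccc(Br)cc23)CC1`, has not yet been measured. It differs from compound 3 in the same way that compound 2 differs from compound 1: bromo in place of chloro on an aromatic carbon, at a place described in the same words. Because the earlier step of a 3.2-fold lower number from compound 1 to compound 2 (0.50 log units; beyond the scatter) lowered the number, the same change is expected to lower the number for compound 4 as well, although one earlier example is a thin base and the new step may turn out smaller or larger. For compound 4 the expected step is a 2.3-fold lower number from compound 3 to compound 4 (0.36 log units; beyond the scatter). For compound 4 the estimate is 1 mg/kg, with a likely range from 0.4 mg/kg to 2.5 mg/kg.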

Compound 4, dose for half-maximal effect: 3.2 mg/kg
Estimate against measurement, compound 4: 3.2-fold (0.51 log units) below, and the stated range ends below it.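

In this assay, bromo in place of chloro on an aromatic carbon gave a 1.4-fold higher number from compound 3 to compound 4 (0.14 log units; within the scatter), so on the core of compound 3 this swap produced no difference that can be told apart from the ordinary spread of repeated measurements. Going by these compounds alone, the benefit seen on the first core therefore did not carry over to the second, and the two results really do differ: the same change on two cores in this assay, a 3.2-fold lower number (0.50 log units; beyond the scatter) from compound 1 to compound 2 and a 1.4-fold higher number (0.14 log units; within the scatter) from compound 3 to compound 4, 4.4-fold (0.65 log units) apart, beyond the scatter of two such steps What this does not show is which feature of the two cores separates the results, or how the swap would behave on any third core, since two cores that differ in more than one place offer only a single comparison.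

The compounds shown leave open how fluoro, iodo or a larger group such as trifluoromethyl would behave at this same place on either core. They also leave open whether an ethoxy group in place of the methoxy group of compound 3 would alter the outcome.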